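This account rests on a few compounds, and the source may have more. Where it says the series, first, only, none or still open, it means among the compounds named here.

Compound 1 `COc1ccc(/C=C/C(=O)Nc2nc3ccc(C)cc3s2)cc1` gives 209 umol/kg in a functional assay on the whole organism (Hindlimb, strain albino) with Mus musculus as the target, in the maximal electroshock model, with a stated time of 0.5 h; on this read-out higher numbers stand for an effect only at larger amounts of compound and lower numbers for an effect already at smaller amounts. Compound 3 `COc1ccc(/C=C/C(=O)Nc2nc3ccc(Cl)cc3s2)cc1` gives 259 umol/kg and compound 2 `Cc1ccc2nc(NC(=O)/C=C/c3ccccc3)sc2c1` gives 380 umol/kg, so compound 1 stands at one end of the three numbers, all of which lie within the usual scatter of one another: a 1.2-fold higher number from compound 1 to compound 3 (0.09 log units; within the scatter) and a 1.8-fold higher number from compound 1 to compound 2 (0.26 log units; within the scatter). Compound 4 `COc1ccc(/C=C/C(=O)Nc2nc3ccc(C)cc3s2)cc1O` differs from compound 1 in a single place, (hydroxy in place of hydrogen on an aromatic carbon). Neither measured step concerns a hydroxy group, and both stayed within the scatter, so no step beyond the scatter is expected in this assay. Compound 4 is therefore estimated at 230 umol/kg, with a range from 110 umol/kg to 480 umol/kg, which would mean an expected step of a 1.1-fold higher number from compound 1 to compound 4 (0.04 log units; within the scatter).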

Compound 4, dose for half-maximal effect: 271 umol/kg
The estimate for compound 4 lay 1.2-fold (0.07 log units) below the measured number; low and high end bracket the measured number.
By their numbers in this assay, from the lowest: compounds 1, 3, 4 and 2 (each within the scatter of the next).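

Hydroxy in place of hydrogen on the aromatic carbon ortho to a methoxy group gives a 1.3-fold higher number from compound 1 to compound 4 (0.11 log units; within the scatter) in this assay, the only step shown that places a group on this carbon. A group with a hydrogen-bond donor can therefore stand here without a step beyond the scatter. Nothing measured here speaks to the reason for this result.

From the compounds shown here alone, whether an amine or a carboxylic acid on this carbon would also stay within the scatter remains open. So does whether hydroxy would behave the same way with chloro in place of methyl on the shared core.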